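Hydroxamic acid series: tetrazole-linked analogue with trifluoromethyl

A few compounds are considered here, and "the series" means these few. Any claim that something is new, unique, unknown or untested is made for them only; others in the source may bear on it.

Measured compounds:
compound 1, `O=C(NO)c1ccc(Sc2nnc(-c3ccccc3)s2)cc1`, 6 nM in an assay on Sf9 cells for inhibition of protein deacetylase HDAC6 (Homo sapiens), read by fluorescence; a higher number here means a weaker inhibitor, a lower number a stronger inhibitor
compound 2, `O=C(NO)c1ccc(Cn2nnc(-c3ccc(S(F)(F)(F)(F)F)cc3)n2)cc1`, 25 nM in this assay

Compound 2 gives the higher of the two numbers in this assay; compound 1 sits well apart from it, a gap beyond the usual scatter. Compound 3, `O=C(NO)c1ccc(Cn2nnc(-c3ccc(C(F)(F)F)cc3)n2)cc1`, is not yet measured. It differs from compound 2 by a group of 4 heavy atoms (1 carbon, 3 fluorine; no ring) in place of a group of 6 heavy atoms (5 fluorine, 1 sulfur; no ring), on an aromatic carbon. Going by the values given here, no measured pair shows this change, so the size of the step is unknown; a modest shift, possibly within the scatter, is expected rather than a large one in either direction. The step from compound 2 to compound 3 is expected to be a 1.3-fold lower number from compound 2 to compound 3 (0.10 log units; within the scatter). Compound 3 is expected to give 20 nM in this assay, with a range from 7 nM to 55 nM.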

Compound 3, half-maximal inhibitory concentration: 11 nM
The estimate for compound 3 lay 1.8-fold (0.26 log units) above the measured number; the measured number falls inside the stated range.
By their numbers in this assay, from the lowest: compounds 1 and 3 (each within the scatter of the next); then compound 2.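

In this assay, placing trifluoromethyl on the aromatic carbon, para to a large group, in place of the group of 5 fluorine and 1 sulfur gives a 2.3-fold lower number from compound 2 to compound 3 (0.36 log units; beyond the scatter). This first step at the position shows that the number responds to this change, although both compounds remain in the same low range. Nothing shown accounts for the shift.

From the compounds shown here alone, how an amine or a carboxylic acid at this carbon would read remains open. A single step also leaves open whether the same change would carry over to another core.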